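This account rests on a few compounds, and the source may have more. Where it says the series, first, only, none or still open, it means among the compounds named here.

Compound 1 `O=C(/C(=C/C1CCCCC1)CCl)c1ccccc1` carries a cyclohexyl group on one double-bonded chain carbon and a chloromethyl group on the other. In a functional assay on SW1573 cells (Homo sapiens) for inhibition, read by sulforhodamine B assay, with a stated time of 48 h (on this read-out higher numbers stand for weaker inhibition of growth and lower numbers for stronger inhibition of growth), compound 1 gives 23000 nM, the highest of the three numbers recorded. Compound 2 `O=C(/C(=C/c1ccccc1)CCl)c1ccccc1` gives 3600 nM in this assay, and compound 3 `O=C(/C(=C/c1ccc(Cl)cc1Cl)CCl)c1ccccc1` gives 3800 nM. Within the data shown here, the only step between two measured compounds that differ in one place is a 6.4-fold lower number from compound 1 to compound 2 (0.81 log units; beyond the scatter); compound 3 stands close to compound 2 on the numbers, and no single-change step connects compound 3 to compound 1 or compound 2.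

Compound 4 `CC(=O)OC/C(=C\C1CCCCC1)C(=O)c1ccccc1` differs from compound 1 in one place: acetoxy in place of chloro on a saturated chain carbon bound to a double-bonded chain carbon. Among the measured compounds shown here, none of the measured steps bears on this change, since the measured steps alter the group on the double-bonded chain carbon and leave the chloromethyl group untouched. For the measured compounds named here, with no comparable step to lean on, the size and direction of the change in this assay are open, and an expectation can rest only on the fact that compound 1 already stands at 23000 nM. Compound 4 is therefore expected to give about 35000 nM, within a range of 12000 nM to 110000 nM. This estimate corresponds to a step of a 1.5-fold higher number from compound 1 to compound 4 (0.18 log units; within the scatter), which is expected to be small relative to the scatter.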

Compound 4, concentration for 50% growth inhibition: 19000 nM
The estimate for compound 4 lay 1.8-fold (0.27 log units) above the measured number; the range from low to high includes it.
By their numbers in this assay, from the lowest: compounds 2 and 3 (each within the scatter of the next); then compounds 4 and 1 (each within the scatter of the next).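

In this assay, the change from chloromethyl to acetoxymethyl gives a 1.2-fold lower number from compound 1 to compound 4 (0.08 log units; within the scatter), so the two values cannot be told apart. Among these compounds, this is the first view of the chloro position itself, since the earlier step altered only the group on the double-bonded chain carbon, and that step lay beyond the scatter. With cyclohexyl on the double-bonded chain carbon, chloro and the larger acetoxy therefore give the same read-out within the scatter, though no information here explains this result.

The compounds shown leave open whether acetoxy in place of chloro would also make no difference beyond the scatter on the phenyl-bearing core of compound 2 or the dichlorophenyl-bearing core of compound 3, as this single pair speaks only for the cyclohexyl series. They also leave open how other groups at the same place, on a saturated chain carbon bound to a double-bonded chain carbon, would read in this assay, for example a hydroxyl, an amine, a carboxylic acid or a longer ester chain.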